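A few compounds are considered here, and "the series" means these few. Any claim that something is new, unique, unknown or untested is made for them only; others in the source may bear on it.

Compound 1 `Cn1cc(-c2cnc3ccc(NC(=O)C4CC4)nc3c2)cn1` gives in a functional assay on A549 cells (Homo sapiens) for antiproliferative activity, read by MTT assay, with a stated time of 48 h (a lower number here means a stronger inhibitor, a higher number a weaker inhibitor), only a limit, > 50000 nM.
Compound 2 `Cn1cc(-c2cnc3ccc(NC(=O)c4ccc(F)cc4)nc3c2)cn1` gives in this assay only a limit, > 50000 nM.
Compound 3 `Cn1cc(-c2cnc3ccnc(NC(=O)C4CC4)c3c2)cn1` gives in this assay only a limit, > 50000 nM.

Among the measured compounds shown here, every value so far sits at the limit of > 50000 nM in this assay, at which 3 of the 3 values shown sit, so the single measured change, (4-fluorophenyl in place of cyclopropyl on a carbonyl carbon), leaves a step that the two limits leave unreadable from compound 1 to compound 2. Compound 4 `Cn1cc(-c2cnc3ccnc(NC(=O)c4ccc(F)cc4)c3c2)cn1` has not yet been measured. It carries the same change as compound 2, (4-fluorophenyl in place of cyclopropyl on a carbonyl carbon), but built on the core of compound 3; the difference between the two cores is not broken down here. For compound 4 the expected step is a step that the limit leaves unreadable from compound 3 to compound 4, an expectation resting on (the limit of > 50000 nM in this assay, at which 3 of the 3 values shown sit), where compound 3 and both compounds of the measured pair sit. Compound 4 is therefore expected to come out near 60000 nM, most likely as a limit again, within a range from 20000 nM to 200000 nM.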

Compound 4, half-maximal inhibitory concentration: > 50000 nM
Compound 4 was reported as a limit; the forecaster's own chance of this, stated with the estimate: 85%; the middle value lies beyond the limit too.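

Compound 3 and compound 4 are both reported only as limits, so no step between them can be read: the limit of > 50000 nM in this assay, at which 4 of the 4 values shown sit.

The compounds shown leave open how strongly any of them acts in this assay, and whether 4-fluorophenyl in place of cyclopropyl changes that.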